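Sulfone series: bromo in place of iodo on the ketone aryl

The source may hold more compounds than are shown below. What is called first, only, known or untested is meant among the compounds shown, and "the series" means these compounds.

Measured in a functional assay on DU-145 cells (Homo sapiens) for inhibition, read by trypan blue exclusion, with a stated time of 96 h; on this read-out higher numbers stand for weaker inhibition of growth and lower numbers for stronger inhibition of growth:
- compound 1 `O=C(/C(=C\c1ccc(O)cc1O)Sc1ccccc1Br)c1ccc(Cl)cc1` gives 50000 nM
- compound 2 `O=C(/C(=C\c1ccc(O)c([N+](=O)[O-])c1)S(=O)(=O)c1ccc(I)cc1)c1ccc(I)cc1` gives 25000 nM

Among the compounds with values here, compound 2 holds the lower of the two numbers so far in this assay. Its nearest neighbour is compound 1, and the gap between the two values lies within the usual scatter of repeated measurements, so no order between compound 1 and compound 2 can be read from these numbers.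

Compound 3 `O=C(/C(=C\c1ccc(O)c([N+](=O)[O-])c1)S(=O)(=O)c1ccc(I)cc1)c1ccc(Br)cc1` is the next compound to be measured in this assay. It differs from compound 2 by a single change: bromo in place of iodo on an aromatic carbon. Within the data shown here, no pair of measured compounds in this set differs by this same change, so nothing measured here tells the size or direction of the step. A step of no more than the scatter is expected in this assay, with no clear direction. Compound 3 is therefore estimated at 25000 nM, with a range of 10000 nM to 60000 nM, which means an expected step of no change at the digits printed from compound 2 to compound 3 (within the scatter).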

Compound 3, concentration for 50% growth inhibition: 25000 nM
Beside the measured number, compound 3's estimate shows no gap at the digits printed, within the range that was stated.
By their numbers in this assay, from the lowest: compounds 2, 3 and 1 (each within the scatter of the next).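

In this assay, within the data shown here, the exchange of 4-iodophenyl for 4-bromophenyl gives no change at the digits printed from compound 2 to compound 3 (within the scatter), the first step in this set that isolates one place, since compound 1 and compound 2 differ in more than one. With the rest of the sulfone held constant, the read-out does not separate bromo from iodo at this position on this single pair. No measurement available here bears on why the two halogens read alike.

As far as these compounds go, whether this position responds to anything other than these two halogens stays open: a methoxy group, an amine or a carboxylic acid there would test that. Also open, from the compounds shown here alone, is whether the same exchange reads alike on a different core, such as that of compound 1.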